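Chloro in Place of Methyl, Across Two Different Cores

The source may report more compounds than this note shows. Statements on the series, on what has been measured and on what is new or still open speak of the compounds shown alone.

Compound 1, `Cc1ccc(NC(=O)COc2nc3ccccc3nc2C)cc1`, in a functional assay on HeLa cells (Homo sapiens) for inhibition, read by MTT assay, with a stated time of 24 h (on this read-out lower numbers stand for stronger inhibition and higher numbers for weaker inhibition), gives 74600 nM. Compound 2, `Cc1nc2ccccc2nc1OCC(=O)Nc1ccc(Cl)cc1`, in this assay reaches only a limit, > 100000 nM. Compound 3, `Cc1ccc(C(=O)Nc2ccc(Cn3c(=O)c(C)nc4ccccc43)cc2)cc1`, in this assay likewise reaches only a limit, > 100000 nM.

From compound 1 to compound 2 the change is chloro in place of methyl on an aromatic carbon, and it gave an at least 1.3-fold higher number from compound 1 to compound 2 (0.12 log units; that floor lies within the scatter). How the cores of compound 1 and compound 3 differ is not broken down here. Compound 4, `Cc1nc2ccccc2n(Cc2ccc(NC(=O)c3ccc(Cl)cc3)cc2)c1=O`, carries the same change as made on compound 3: chloro in place of methyl on an aromatic carbon.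

Compound 3 sits at the limit of > 100000 nM in this assay, at which 2 of the 3 values shown sit. Since that earlier step from compound 1 to compound 2 stayed within the scatter, and compound 3 already gives only a limit, compound 4 is expected to show a step that the limit leaves unreadable from compound 3 to compound 4 in this assay. For compound 4 the estimate is 150000 nM, between 60000 nM and 500000 nM.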

Compound 4, half-maximal inhibitory concentration: > 100000 nM
Compound 4 ended at the assay's limit (the forecaster's own chance of this, stated with the estimate: 80%); the middle value is on the limit's open side.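

Going by these compounds alone, compound 3 and compound 4 each give only a limit in this assay, so no step between them can be read: the limit of > 100000 nM in this assay, at which 3 of the 4 values shown sit. On these data alone, whether chloro in place of methyl shifts the number on the core of compound 3 stays open.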